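Methoxy removal on the ketone aryl of compound 2

A few compounds are considered here, and "the series" means these few. Any claim that something is new, unique, unknown or untested is made for them only; others in the source may bear on it.

Two compounds of the series have been run in a functional assay on T47D cells (Homo sapiens) for inhibition, read by sulforhodamine B assay, with a stated time of 48 h; on this read-out lower numbers stand for stronger inhibition of growth and higher numbers for weaker inhibition of growth. Compound 1 `COc1cc(-c2cc(/C=C/C(=O)c3ccc(N)cc3)[nH]n2)cc(OC)c1OC` gives 4300 nM. Compound 2 `COc1ccc(C(=O)/C=C/c2cc(-c3cc(OC)c(OC)c(OC)c3)n[nH]2)cc1OC` gives 4360 nM. Among the compounds with values here, the one step between them, a 1.0-fold higher number from compound 1 to compound 2 (0.01 log units; within the scatter), is a swap of the aryl on the carbonyl carbon with no change beyond the scatter. On these two numbers compound 2 holds the higher value, yet its gap to compound 1 lies within the scatter, so the pair reads as equal.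

Compound 3 `COc1ccc(C(=O)/C=C/c2cc(-c3cc(OC)c(OC)c(OC)c3)n[nH]2)cc1` is not yet measured. It differs from compound 2 by hydrogen in place of methoxy on an aromatic carbon; cut one bond further out the change reads 3,4-dimethoxyphenyl to 4-methoxyphenyl. Within the data shown here, no measured step removes a methoxy from this ring. Among the measured compounds shown here, the only step that touches the same region, from compound 1 to compound 2, replaced the whole aryl on the carbonyl carbon and left the number within the scatter, which argues that this part of the molecule is tolerant. In this assay the expected step is therefore a 1.0-fold higher number from compound 2 to compound 3 (0.01 log units; within the scatter), with no clear direction.

Compound 3 is estimated at 4500 nM, within 1500 nM to 13000 nM.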

Compound 3, concentration for total growth inhibition: 13000 nM
For compound 3 the middle estimate is 2.9-fold (0.46 log units) below the measured one, and the stated range covers the measured number.
By their numbers in this assay, from the lowest: compounds 1 and 2 (each within the scatter of the next); then compound 3.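

In this assay, the aryl on the carbonyl carbon proves less tolerant than the flat step a 1.0-fold higher number from compound 1 to compound 2 (0.01 log units; within the scatter) suggested: the change from 3,4-dimethoxyphenyl to 4-methoxyphenyl gives a 3.0-fold higher number from compound 2 to compound 3 (0.47 log units; beyond the scatter), so the methoxy that leaves, ortho to a methoxy group, carries weight in this read-out. The change from 4-aminophenyl to 4-methoxyphenyl gives a 3.0-fold higher number from compound 1 to compound 3 (0.48 log units; beyond the scatter), so 4-methoxyphenyl reads weaker against both other aryls, while 4-aminophenyl and 3,4-dimethoxyphenyl remain equal within the scatter; the earlier flat step therefore marks two aryls that match, not a region indifferent to its substituents. Nothing at hand on these compounds accounts for the size of either step.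

Open, on these data alone, is whether the methoxy itself is needed, or whether a hydroxyl, a chlorine or an ethoxy group on the same aromatic carbon would return the number to that of compound 2 at 4360 nM. Also open, as far as these compounds go, is whether a dimethylamino group in place of the amino group of compound 1 would stay near the number of compound 1 at 4300 nM or move towards the weaker number of compound 3.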